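Swapping ethyl for hydroxy in a purine amide series

The source may hold more compounds than are shown below. What is called first, only, known or untested is meant among the compounds shown, and "the series" means these compounds.

Of the compounds shown here, two have been tested so far. Compound 1 `O=C(CN(c1nc(Cl)nc2c1ncn2C1CCCCO1)C1CC1)N[C@@H](CC(=O)OCc1ccccc1)C(=O)OCc1ccccc1` gives 25.1% in a functional assay on the whole organism with Mus musculus as the target, with a stated time of 90 min, at a dose of 25 umol/kg by the oral route (a higher number here means a stronger effect of the compound at the dose given, a lower number a weaker effect), and compound 2 `CC[C@H](C)[C@H](NC(=O)CN(c1nc(Cl)nc2c1ncn2C1CCCCO1)C1CC1)C(=O)OCc1ccccc1` gives 22.6% in the same assay. Compound 2 thus holds the lower of the two numbers, but the difference to compound 1 is within the usual scatter of repeated measurements, so the two compounds cannot be told apart on these data.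

Compound 3 `C[C@@H](O)[C@H](NC(=O)CN(c1nc(Cl)nc2c1ncn2C1CCCCO1)C1CC1)C(=O)OCc1ccccc1` is the next compound, not yet measured. It differs from compound 2 in one place: hydroxy in place of ethyl on a saturated chain carbon bound to two saturated chain carbons.

Within the data shown here, only one measured step is available as a guide, the change from compound 1 to compound 2, which read a number 2.5 percentage points lower from compound 1 to compound 2 (within the scatter). That step altered a different group than the one exchanged here, so it bears on the present change only loosely; it shows, though, that reshaping this part of the molecule left the activity unmoved. No step beyond the scatter is therefore expected from compound 2 to compound 3, an expected a number 0.4 percentage points higher from compound 2 to compound 3 (within the scatter). For compound 3 the activity is estimated at 23%, with a range from 8% to 40%.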

Compound 3, a percentage reported as activity, at one dose (the size of the read-out at that dose, not a potency): 23.4%
Compound 3: middle estimate off by 0.4 percentage points, on the low side, and the stated range covers the measured number.
By their numbers in this assay, from the lowest: compounds 2, 3 and 1 (each within the scatter of the next).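

In this assay, putting hydroxy in place of ethyl on a saturated chain carbon bound to two saturated chain carbons gives a number 0.8 percentage points higher from compound 2 to compound 3 (within the scatter) and so does not separate the two compounds, even though the entering group brings 1 hydrogen-bond donor and 1 hydrogen-bond acceptor and the leaving group brings neither. Compared with the larger side chain, 1-hydroxyethyl in place of (benzyloxycarbonyl)methyl gives a number 1.7 percentage points lower from compound 1 to compound 3 (within the scatter) in this assay, so sec-butyl, 1-hydroxyethyl and (benzyloxycarbonyl)methyl now form a set of three side chains that cannot be told apart on these numbers. Nothing at hand explains why these exchanges leave the compounds indistinguishable.

Whether an amine, a carboxylic acid or a longer chain at this place would produce a step beyond the scatter remains open, since the three side chains shown include none of these. Each number is also a read-out at a single dose rather than a potency, so compounds that look alike here could still differ at other doses.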